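Replacing a chlorophenyl on the triazole ring of a weak antiproliferative

The compounds below may be only part of what the source reports. "The series", "measured", "known", "first", "only" and "open" are said of these compounds alone.

Measured compounds:
compound 1, `CN(CCNCc1cn(-c2cccc(Cl)c2)nn1)CCNc1ccnc2cc(Cl)ccc12`, 17000 nM
compound 2, `CN(CCNCc1cn(-c2ccccc2Cl)nn1)CCNc1ccnc2cc(Cl)ccc12`, 20000 nM

In a functional assay on NCI-H460 cells (Homo sapiens) for antiproliferative activity, read by sulforhodamine B assay, with a stated time of 72 h (a lower number here means a stronger inhibitor, a higher number a weaker inhibitor), compound 1 holds the lowest of the two numbers, and compound 2 sits within the scatter of it, as the step of a 1.2-fold higher number from compound 1 to compound 2 (0.07 log units; within the scatter) shows. Compound 3, `CN(CCNCc1cn(CCC(=O)Nc2ccccn2)nn1)CCNc1ccnc2cc(Cl)ccc12`, has not been measured. It differs from compound 1 as follows: 2-((pyridin-2-yl)carbamoyl)ethyl in place of 3-chlorophenyl on an aromatic nitrogen. Among the measured compounds shown here, the one measured step swaps only the position of a chlorine on a phenyl ring and says little about this larger exchange, so no direction can be drawn from it. The expected step is a 1.2-fold higher number from compound 1 to compound 3 (0.07 log units; within the scatter), with wide uncertainty. Compound 3 is estimated at 20000 nM, expected between 6000 nM and 70000 nM.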

Compound 3, half-maximal inhibitory concentration: > 200000 nM
Compound 3 ended at the assay's limit (the forecaster's own chance of this, stated with the estimate: 15%); middle value at least 10-fold (1.00 log units) from the limit.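

In this assay compound 3 gives > 200000 nM, which is a limit of the assay and not a number: the limit of > 200000 nM in this assay, at which 1 of the 3 values shown sits. Moving the chlorine around the phenyl ring left the reading within the scatter, but this aromatic nitrogen does respond to a larger exchange: 2-((pyridin-2-yl)carbamoyl)ethyl in place of 3-chlorophenyl gives an at least 11-fold higher number from compound 1 to compound 3 (1.07 log units; beyond the scatter), and in place of 2-chlorophenyl it gives an at least 10-fold higher number from compound 2 to compound 3 (1.00 log units; beyond the scatter).

The exchange alters the ring, the chain and the carbonyl at once, so the compounds shown cannot tell which part carries the loss. From the compounds shown here alone, whether a benzyl group or a plain ethyl chain on this nitrogen would keep the activity of compound 1 stays open.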